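The source may hold more compounds than are shown below. What is called first, only, known or untested is meant among the compounds shown, and "the series" means these compounds.

Measured compounds:
- compound 1, `CCSC(=S)SCC(=O)c1ccc(C)cc1`: 1250 nM
- compound 2, `CCSC(=S)SCC(=O)c1ccc(NS(C)(=O)=O)cc1`: 1090 nM
- compound 3, `CCSC(=S)SCC(=O)c1ccc(NS(=O)(=O)c2ccccc2)cc1`: 382 nM

In an assay on HEK293 cells for inhibition of protein deacetylase HDAC6 (Homo sapiens) (a lower number here means a stronger inhibitor, a higher number a weaker inhibitor), compound 2 gives a number that is the second highest of the three, standing close to compound 1 but well apart from compound 3, which gives the lowest number of the set. Compound 4, `CCSC(=S)SCC(=O)c1ccc(CN(C)C(C)=O)cc1`, has not been measured; it differs from compound 2 in one place: (acetyl(methyl)amino)methyl in place of methanesulfonamido on an aromatic carbon. Within the data shown here, two measured steps bear on this position. The step of a 1.1-fold lower number from compound 1 to compound 2 (0.06 log units; within the scatter) shows that exchanging methyl for methanesulfonamido at this aromatic carbon changed little. The step of a 2.9-fold lower number from compound 2 to compound 3 (0.46 log units; beyond the scatter) shows that enlarging the group on the sulfonyl sulfur to phenyl gave a modest gain. Among the measured compounds shown here, neither step involves a group like the (acetyl(methyl)amino)methyl entering here, so no measured step directly predicts the result. Given that small changes at this position left the number little moved, a step of a 1.1-fold lower number from compound 2 to compound 4 (0.04 log units; within the scatter) is expected, and compound 4 is estimated at 1000 nM with a range from 400 nM to 2500 nM.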

Compound 4, half-maximal inhibitory concentration: 256 nM
Beside the measured number, compound 4's estimate is 3.9-fold (0.59 log units) above it, outside the stated range (below it).
By their numbers in this assay, from the lowest: compounds 4 and 3 (each within the scatter of the next); then compounds 2 and 1 (each within the scatter of the next).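

In this assay this aromatic carbon proved able to move the number after all, with a 4.3-fold lower number from compound 2 to compound 4 (0.63 log units; beyond the scatter) and a 4.9-fold lower number from compound 1 to compound 4 (0.69 log units; beyond the scatter) as well, whereas methanesulfonamido in place of methyl had changed nothing beyond the scatter. The new group has no ring and 0 hydrogen-bond donors, so neither a phenyl on a sulfonyl sulfur nor the sulfonamide hydrogen is needed for a step of this size here. Nothing measured in this set explains the step.

The compounds shown leave open which part of (acetyl(methyl)amino)methyl carries the step: the saturated chain carbon, the methyl on nitrogen or the acetyl. A free aminomethyl group, an acetylamino group set directly on the aromatic carbon, or a longer acyl chain such as propionyl would separate these parts, and none of them stands among these compounds.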